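From propanoyl to tert-butyl: working notes

The source may report more compounds than this note shows. Statements on the series, on what has been measured and on what is new or still open speak of the compounds shown alone.

In a functional assay on L5178Y cells (Mus musculus) for antiproliferative activity, read by MTT assay (on this read-out lower numbers stand for stronger inhibition and higher numbers for weaker inhibition), compound 1 `CC(=O)c1ccc(OCCCN2CCN(c3ncccn3)CC2)cc1` gives 53.2 nM and compound 2 `CCC(=O)c1ccc(OCCCN2CCN(c3ncccn3)CC2)cc1` gives 36.9 nM. For the measured compounds named here, the only measured single-site change, a 1.4-fold lower number from compound 1 to compound 2 (0.16 log units; within the scatter), places a methyl in place of hydrogen on the saturated chain carbon bound to the carbonyl carbon. Compound 2 therefore stands together with compound 1 at the high end of the three numbers. Compound 3 `CCC(C)(C)c1ccc(OCCCCN2CCN(c3cccnc3)CC2)cc1` gives 3.23 nM, a lower number than compound 2 by more than the scatter. It differs from compound 2 in more than one place, so no single change can be read from that gap.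

Compound 4 `CC(C)(C)c1ccc(OCCCN2CCN(c3ncccn3)CC2)cc1` remains unmeasured. The change from compound 2 is tert-butyl in place of propanoyl on an aromatic carbon. Going by the values given here, no measured step tests this replacement. The small step between compound 1 and compound 2 only alters the chain on the carbonyl and says little about removing it. Among the compounds with values here, compound 3, at 3.23 nM, is the sole measured compound without that carbonyl, which gives weak support for a lower number, of uncertain size. The expected step is a 3.1-fold lower number from compound 2 to compound 4 (0.49 log units; beyond the scatter). Compound 4 is estimated at 12 nM, with an expected range of 4 nM to 40 nM.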

Compound 4, half-maximal inhibitory concentration: 25.6 nM
For compound 4 the middle estimate is 2.1-fold (0.33 log units) below the measured one, and the stated range covers the measured number.
By their numbers in this assay, from the lowest: compound 3; then compounds 4, 2 and 1 (each within the scatter of the next, the first and the last beyond it).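

In this assay, the aromatic carbon para to a large group accepts tert-butyl in place of propanoyl with a 1.4-fold lower number from compound 2 to compound 4 (0.16 log units; within the scatter), so on this core the carbonyl can be lost without the number leaving the usual scatter of compound 2. Against the shorter acetyl the same tert-butyl gives a 2.1-fold lower number from compound 1 to compound 4 (0.32 log units; beyond the scatter), a modest step, and this is the only step at this position that is printed as beyond the scatter, so the three groups tested here span a narrow band whose two ends alone can be told apart. No supporting measurement bears on why these groups give such close numbers.

As far as these compounds go, whether an amine, a carboxylic acid or a longer chain on this aromatic carbon would stay within the same narrow band remains open. For the compounds shown here, the much lower number of compound 3, 3.23 nM, also remains unassigned to any single feature, since compound 3 differs from compound 4 in more than one place and no single-site step connects it to the other compounds.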